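This account rests on a few compounds, and the source may have more. Where it says the series, first, only, none or still open, it means among the compounds named here.

Measured in a functional assay on HepG2 cells (Homo sapiens) for antiproliferative activity, read by MTT assay, with a stated time of 48 h; on this read-out higher numbers stand for weaker inhibition and lower numbers for stronger inhibition:
- compound 1 `O=C(CN1CCCCC1)Nc1ccc2ncnc(Nc3cccc(C(F)(F)F)c3)c2c1`: > 100000 nM (a limit)
- compound 2 `O=C(CN1CCCCC1)Nc1ccc2ncnc(Nc3ccc(Cl)cc3)c2c1`: 16000 nM
- compound 3 `O=C(CN1CCCC1)Nc1ccc2ncnc(Nc3ccc(Cl)c(C(F)(F)F)c3)c2c1`: > 100000 nM (a limit)

Not yet measured: compound 4 `O=C(CN1CCCCC1)Nc1ccc2ncnc(Nc3ccc(Cl)c(C(F)(F)F)c3)c2c1`.

Compound 3 stands at > 100000 nM, which is a limit and not a number. It sits with compound 1 at the limit of > 100000 nM in this assay, at which 2 of the 3 values shown sit.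

The change to compound 4 is piperidin-1-yl in place of pyrrolidin-1-yl on a saturated chain carbon bound to a carbonyl carbon. The rest of compound 3 stays as it is.

For the measured compounds named here, the only measured step, an at least 6.2-fold lower number from compound 1 to compound 2 (0.79 log units; beyond the scatter), lies at a different place, on a nitrogen on an aromatic ring, and piperidin-1-yl is present on both sides of it. Going by the values given here, it was at least modest, but it says nothing directly about the size of a change from pyrrolidin-1-yl to piperidin-1-yl, and no measured pair isolates that change. With piperidin-1-yl, compound 2 gives 16000 nM, whereas compound 1 carries the same group and gives no number.

No step beyond the scatter is therefore expected in this assay, and a reading at the limit remains the likeliest outcome. The expected change is an at least 1.2-fold lower number from compound 3 to compound 4 (0.09 log units; that floor lies within the scatter). The estimate for compound 4 is 80000 nM, with an expected range from 30000 nM to 150000 nM.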

Compound 4, half-maximal inhibitory concentration: > 100000 nM
Compound 4 gave a limit, no number; the forecaster's own chance of this, stated with the estimate: 65%; middle value at least 1.2-fold (0.09 log units) away from the limit.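

In this assay compound 4 gives > 100000 nM, which is a limit and not a number. For the compounds shown here, the one readable new step is trifluoromethyl in place of hydrogen on an aromatic carbon, an at least 6.2-fold higher number from compound 2 to compound 4 (0.79 log units; beyond the scatter), so with piperidin-1-yl kept, adding trifluoromethyl to the 4-chlorophenyl group weakens inhibition beyond the scatter, and piperidin-1-yl alone does not secure a measurable value. The steps from compound 3 and from compound 1 to compound 4 cannot be read, both ends being limits, so piperidin-1-yl in place of pyrrolidin-1-yl still has no size, and the series now sits mostly at the top of the range: the limit of > 100000 nM in this assay, at which 3 of the 4 values shown sit.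

As far as these compounds go, the effect of pyrrolidin-1-yl against piperidin-1-yl stays open until a pair is available with the 4-chlorophenyl group, the only setting here with a number, where compound 2 gives 16000 nM. Also open, from the compounds shown here alone, is whether a morpholine or a dimethylamino group, on a saturated chain carbon bound to a carbonyl carbon, would give a measurable value with that same group.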